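The compounds below may be only part of what the source reports. "The series", "measured", "known", "first", "only" and "open" are said of these compounds alone.

Of the compounds shown here, three sharing one core have been tested in an ADME assay on HUVEC cells (Homo sapiens) for antiproliferative activity, read by MTT assay, with a stated time of 48 h; a higher number here means a weaker inhibitor, a lower number a stronger inhibitor. Compound 1 `N#CC1=C(N)Oc2c(c3nc4ccccc4nc3c3ccccc23)C12C(=O)N(Cc1cnnn1-c1ccc(F)cc1)c1ccccc12` carries a 4-fluorophenyl on an aromatic nitrogen. In this assay compound 1 reaches only a limit, > 50000 nM. Compound 2 `Cc1ccc(-n2nncc2CN2C(=O)C3(C(C#N)=C(N)Oc4c3c3nc5ccccc5nc3c3ccccc43)c3ccccc32)cc1C` has a 3,4-dimethylphenyl in place of that 4-fluorophenyl. In this assay compound 2 likewise gives only a limit, > 50000 nM. The step that the two limits leave unreadable from compound 1 to compound 2 therefore cannot be read. Compound 3 `Cc1cccc(-n2nncc2CN2C(=O)C3(C(C#N)=C(N)Oc4c(N)cc5nc6ccccc6nc5c43)c3ccccc32)c1` carries a 3-methylphenyl on the aromatic nitrogen and has a different core. In this assay compound 3 also stops at a limit, > 50000 nM. Within the data shown here, all three values sit at the limit of > 50000 nM in this assay, at which 3 of the 3 values shown sit, so no measured step in this set has a readable size, and nothing shows how a change at this nitrogen moves the activity.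

Compound 4 `N#CC1=C(N)Oc2c(N)cc3nc4ccccc4nc3c2C12C(=O)N(Cc1cnnn1-c1ccc(Cl)cc1Cl)c1ccccc12` is not yet measured. It differs from compound 3 in one place: 2,4-dichlorophenyl in place of 3-methylphenyl on an aromatic nitrogen. Among the measured compounds shown here, the only comparable exchange, from compound 1 to compound 2, left both compounds at the limit. Because every measured neighbour sits at the limit of > 50000 nM in this assay, at which 3 of the 3 values shown sit, compound 4 is expected to give about 60000 nM, within a range from 20000 nM to 200000 nM. The step that the limit leaves unreadable from compound 3 to compound 4 is accordingly expected to be none beyond the scatter.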

Compound 4, half-maximal inhibitory concentration: > 50000 nM
Compound 4 was reported as a limit (the forecaster's own chance of this, stated with the estimate: 80%); the middle value lies beyond the limit too.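

Compound 3 and compound 4 both stop at a limit, so the exchange of 3-methylphenyl for 2,4-dichlorophenyl has no readable size: the limit of > 50000 nM in this assay, at which 4 of the 4 values shown sit. In this assay the compounds shown leave open whether any change on this aromatic nitrogen can move the activity at all.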